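Aminomethylpiperidine Side Chains and Serotonin 1B Receptor Binding

The compounds below may be only part of what the source reports. "The series", "measured", "known", "first", "only" and "open" are said of these compounds alone.

Measured compounds:
compound 1 `c1ccc2c(c1)CCC2NC1CCN(CCCc2c[nH]c3ccc(-n4cnnc4)cc23)CC1`: 280 nM
compound 2 `CC(C)=CCCN(C)C1CCN(CCCc2c[nH]c3ccc(-n4cnnc4)cc23)CC1`: 24 nM
compound 3 `c1ccc(NCC2CCN(CCCc3c[nH]c4ccc(-n5cnnc5)cc34)CC2)nc1`: 3.3 nM

In an assay on CHO cells for displacement of a labelled ligand from 5-hydroxytryptamine receptor 1B (Homo sapiens) (a higher number here means a weaker inhibitor, a lower number a stronger inhibitor), compound 3 gives 3.3 nM, the lowest of the three numbers. The nearest is compound 2, separated by a 7.3-fold lower number from compound 2 to compound 3 (0.86 log units; beyond the scatter), and the furthest is compound 1, separated by an 85-fold lower number from compound 1 to compound 3 (1.93 log units; beyond the scatter); both steps lie beyond the usual scatter, so compound 3 stands apart as the strongest inhibitor of the three.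

Compound 4 `CC(=O)Nc1ccc([C@@H](C)NCC2CCN(CCCc3c[nH]c4ccc(-n5cnnc5)cc34)CC2)cc1` differs from compound 3 at the amine nitrogen: 1-(4-acetamidophenyl)ethyl in place of pyridin-2-yl on an amine nitrogen. Within the data shown here, no measured pair shows this exact exchange. The steps from compound 1 and compound 2 to compound 3 show that what sits on this part of the shared core can move the number widely, with an 85-fold lower number from compound 1 to compound 3 (1.93 log units; beyond the scatter) being the largest. The exchange here removes the pyridin-2-yl group that compound 3 carries and puts in its place a larger 1-(4-acetamidophenyl)ethyl group, so a shift away from compound 3 in the direction of a higher number is expected, of moderate size.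

For compound 4 the expected step is a 3.6-fold higher number from compound 3 to compound 4 (0.56 log units; beyond the scatter), and the estimate in this assay is 12 nM, within a range from 2.5 nM to 60 nM.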

Compound 4, half-maximal inhibitory concentration: 8.9 nM
Beside the measured number, compound 4's estimate is 1.3-fold (0.13 log units) above it; the measured number falls inside the stated range.
By their numbers in this assay, from the lowest: compound 3; then compound 4; then compound 2; then compound 1.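

Among these compounds, the step of a 2.7-fold higher number from compound 3 to compound 4 (0.43 log units; beyond the scatter) in this assay is the first reading of a change on the amine nitrogen alone, with the rest of compound 3 held in place. It shows that this position accepts a much larger group at a modest cost: 1-(4-acetamidophenyl)ethyl, with 12 heavy atoms, a hydrogen-bond donor and a defined stereocentre, replaces pyridin-2-yl, with 6 heavy atoms, and the step remains well short of an 85-fold lower number from compound 1 to compound 3 (1.93 log units; beyond the scatter), which involves a change to the whole side chain. The change still lies beyond the scatter, so compound 3 keeps the lower number, but nothing available explains the step or ties it to any one feature of the entering group.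

The compounds shown leave open which part of the 1-(4-acetamidophenyl)ethyl group accounts for the step, a question that a plain benzyl group or a 1-phenylethyl group on the same nitrogen could help to separate. As far as these compounds go, whether the opposite configuration at the stereocentre would give a similar number in this assay also remains open.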